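This account rests on a few compounds, and the source may have more. Where it says the series, first, only, none or still open, it means among the compounds named here.

Compound 1 `O=S(=O)(c1ccc(Cl)cc1)N1Cc2c[nH]nc2CC1c1cncnc1` is the more stable of the two compounds measured in an ADME assay on microsomes from liver (Homo sapiens) for metabolic stability, using NADPH, with a stated time of 30 min, in the presence of a further agent that is not named here; on this read-out higher numbers stand for a more stable compound and lower numbers for a less stable compound: compound 1 gives 67%, while compound 2 `CC[C@@H]1c2c[nH]nc2C[C@H](c2ccc(Cl)cc2)N1S(=O)(=O)c1ccc(Cl)cc1` gives 4%, a gap that lies beyond the scatter of the method. Compound 3 `O=S(=O)(c1ccc(Cl)cc1)N1Cc2c[nH]nc2CC1c1ccc(Cl)cc1` keeps the core of compound 1 and carries 4-chlorophenyl in place of pyrimidin-5-yl on a saturated ring carbon. Among the measured compounds shown here, no measured pair shows this single change, so its effect must be estimated. Because compound 2, which also bears a 4-chlorophenyl group, gives 4%, a drop in this assay is expected, with the step of a number 37 percentage points lower from compound 1 to compound 3 (beyond the scatter). Compound 3 is therefore estimated at 30%, in a range from 10% to 55%.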

Compound 3, percent of the compound remaining: 12%
Beside the measured number, compound 3's estimate is 18 percentage points above it; measured number inside the range.
By their numbers in this assay, from the lowest: compounds 2 and 3 (each within the scatter of the next); then compound 1.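

Until now the effect of this single change could only be estimated, but it now has a measured size: in this assay putting 4-chlorophenyl in place of pyrimidin-5-yl on this saturated ring carbon is a number 55 percentage points lower from compound 1 to compound 3 (beyond the scatter) and so a large step. With the rest of the core of compound 1 unchanged, the group at this one place can by itself shift the read-out strongly. Nothing measured here explains the drop.

Still open, as far as these compounds go, is how a plain phenyl or a pyridinyl group would behave at this place. Whether an amine or a carboxylic acid on the ring would hold the higher number is equally unknown.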